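Trimming One Methoxy Group on the Pyrazole Side

The source may report more compounds than this note shows. Statements on the series, on what has been measured and on what is new or still open speak of the compounds shown alone.

Compound 1 `COc1cc(-c2cc(/C=C/C(=O)c3ccc(N)cc3)[nH]n2)cc(OC)c1OC` carries a methoxy-bearing phenyl ring on one side of its core and a 4-aminophenyl ketone on the other. In a functional assay on SF-268 cells (Homo sapiens) for inhibition, read by sulforhodamine B assay, with a stated time of 48 h (on this read-out higher numbers stand for lower toxicity in this test and lower numbers for higher toxicity in this test), compound 1 gives 9160 nM, the lowest of the two plain numbers recorded here. Compound 2 `COc1ccc(-c2cc(/C=C/C(=O)c3ccc(OC)c(OC)c3)[nH]n2)cc1` gives 27300 nM in this assay. For compound 3 `COc1cc(-c2cc(/C=C/C(=O)c3ccc(Cl)c(Cl)c3)[nH]n2)cc(OC)c1OC` only a limit is recorded, > 100000 nM. Among the measured compounds shown here, the single measured step, an at least 10-fold higher number from compound 1 to compound 3 (1.03 log units; beyond the scatter), alters the ketone side and is bounded by the limit of > 100000 nM in this assay, at which 1 of the 3 values shown sits. Compound 4 `COc1ccc(-c2cc(/C=C/C(=O)c3ccc(N)cc3)[nH]n2)cc1OC` differs from compound 1 on the opposite side: hydrogen in place of methoxy on an aromatic carbon. For the measured compounds named here, no measured step touches this change, so the expectation rests on compound 1 alone, and only a small shift is expected: a 1.6-fold higher number from compound 1 to compound 4 (0.21 log units; within the scatter). Compound 4 is therefore estimated at 15000 nM, within 6000 nM to 40000 nM.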

Compound 4, concentration lethal to 50% of the cells: 11200 nM
Compound 4: the middle estimate sits 1.3-fold (0.13 log units) above what was measured, and the stated range covers the measured number.
By their numbers in this assay, from the lowest: compounds 1 and 4 (each within the scatter of the next); then compound 2. At a limit, above all of these: compound 3.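

Hydrogen in place of methoxy on this aromatic carbon gives a 1.2-fold higher number from compound 1 to compound 4 (0.09 log units; within the scatter). Among the compounds shown here, the only earlier step changed the ketone side, so this is the first reading from the opposite ring, and there this methoxy group can be lost without a shift beyond the scatter. No recorded property bears on this step, so the data offer no explanation for it.

Still open, as far as these compounds go, is whether a hydroxyl group or an ethoxy group at this place would leave the number just as close. From the compounds shown here alone, it is also open whether the remaining methoxy groups can be replaced in the same way.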